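The source may report more compounds than this note shows. Statements on the series, on what has been measured and on what is new or still open speak of the compounds shown alone.

Measured in a functional assay on MCF7 cells (Homo sapiens) for antiproliferative activity, read by MTT assay, with a stated time of 24 h; on this read-out lower numbers stand for stronger inhibition and higher numbers for weaker inhibition:
- Compound 1 `CCN(CC)CCNC(=O)C1CC=C(C(CC)(CC)c2ccc(C#CC(C)(O)CC)c(C)c2)N1CC`: 600 nM
- Compound 2 `CCN(CC)CCNC(=O)C1CC=C(C(CC)(CC)c2ccc(C#CC(O)C3CCCCC3)c(C)c2)N1CC`: 2790 nM

Compound 2 holds the higher of the two numbers. Compound 3 `CCN(CC)CCNC(=O)C1CC=C(C(CC)(CC)c2ccc(/C=C/C(C)(O)CC)c(C)c2)N1CC` departs from it thus: a group of 7 heavy atoms (6 carbon, 1 oxygen; no ring) in place of a group of 10 heavy atoms (9 carbon, 1 oxygen; one six-membered non-aromatic ring of carbon only), on an aromatic carbon. The six-membered non-aromatic ring and the triple bond leave, a double bond enters, and the 1-hydroxy-1-methylpropyl of compound 1 returns. Within the data shown here, the one measured step that bears on this is a 4.7-fold higher number from compound 1 to compound 2 (0.67 log units; beyond the scatter). Read backwards, it suggests a lower number in this assay, though no measured step covers the double bond. The expected step is a 3.1-fold lower number from compound 2 to compound 3 (0.49 log units; beyond the scatter). Compound 3 is estimated at 900 nM, with an expected range of 300 nM to 2700 nM.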

Compound 3, half-maximal inhibitory concentration: "not active" (no number reported)
Compound 3 has no reported number here, and the estimate cannot be compared.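

In this assay, among these compounds, compound 3 is reported as "not active" without a number, so no step from compound 1 or compound 2 to compound 3 can be read. The compounds shown leave open how the double bond compares with the triple bond, and no evidence at hand accounts for this result.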